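This account rests on a few compounds, and the source may have more. Where it says the series, first, only, none or still open, it means among the compounds named here.

In a functional assay on MDA-MB-468 cells (Homo sapiens) for antiproliferative activity, read by MTT assay, with a stated time of 72 h (on this read-out lower numbers stand for stronger inhibition and higher numbers for weaker inhibition), compound 1 `O=C(Nc1ccc(Cl)c(-c2nnc3c(Cl)cccn23)c1)c1ccc(F)cc1Cl` gives > 100000 nM as a limit of the assay, not a number. Compound 2 `O=C(Nc1ccc(Cl)c(-c2nnc3c(Cl)cccn23)c1)c1cccnc1` gives > 100000 nM as a limit too. Compound 3 `O=C(Nc1ccc(Cl)c(-c2nnc3c(Cl)cccn23)c1)c1cccc(Cl)c1` gives 54800 nM as a true number. Compound 4 `CS(=O)(=O)c1ccc(C(=O)Nc2ccc(Cl)c(-c3nnc4c(Cl)cccn34)c2)c(Cl)c1` differs from compound 1 in one place, with methylsulfonyl in place of fluoro on an aromatic carbon and nothing else changed. Going by the values given here, no measured step makes this change alone. The nearest evidence replaces the whole group on the carbonyl carbon: one is a step that the two limits leave unreadable from compound 1 to compound 2 and the other is an at least 1.8-fold lower number from compound 1 to compound 3 (0.26 log units; that floor lies within the scatter) and neither reads as a step beyond the scatter. So no step beyond the scatter is expected in this assay and the estimated step is an at least 1.6-fold lower number from compound 1 to compound 4 (0.22 log units; that floor lies within the scatter) as a small one at best. For compound 4 the expected value is 60000 nM within an estimated range from 15000 nM to 200000 nM.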

Compound 4, half-maximal inhibitory concentration: > 100000 nM
Compound 4: only a limit was reported; the forecaster's own chance of this, stated with the estimate: 45%; middle value at least 1.6-fold (0.22 log units) from the limit.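

No step can be read from compound 1 to compound 4, since both values are limits and not numbers: the limit of > 100000 nM in this assay, at which 3 of the 4 values shown sit. On these data alone, whether methylsulfonyl in place of fluoro changes the inhibition at all stays open.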